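This account rests on a few compounds, and the source may have more. Where it says the series, first, only, none or still open, it means among the compounds named here.

Measured compounds:
Compound 1 `O=C(NC(=S)Nc1nc2cc([N+](=O)[O-])ccc2s1)c1ccccc1` — 75100 nM
Compound 2 `CCCCC(=O)NC(=S)Nc1nc2cc([N+](=O)[O-])ccc2s1` — "not determined" (no result reported)
Compound 3 `Nc1ccc2sc(NC(=S)NC(=O)N3CCOCC3)nc2c1` — 45300 nM

All numbers come from a functional assay on HeLa cells (Homo sapiens) for cytotoxicity, read by MTT assay, with a stated time of 24 h; a lower number here means a stronger inhibitor, a higher number a weaker inhibitor. In this assay compound 1 gives 75100 nM and compound 3 gives 45300 nM. The two values sit within the usual scatter of each other, so neither is set ahead of the other; both show weak inhibition. Compound 2 stands apart: it carries the nitro-bearing core of compound 1, but no number exists for it, so its place among the measured compounds is a blank.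

Compound 4 `CCCCC(=O)NC(=S)Nc1nc2ccccc2s1` is the next compound. The change from compound 2: hydrogen in place of nitro on an aromatic carbon. For the measured compounds named here, no step between measured compounds covers this change, and nothing measured here separates a nitro-bearing core from one without it. In this assay the step is expected to be small, likely none beyond the scatter, with no direction to be assigned.

Going by the values given here, the only anchors are compound 1 at 75100 nM and compound 3 at 45300 nM, both weak. On that basis compound 4 is expected near 60000 nM, with a range from 20000 nM to 200000 nM.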

Compound 4, half-maximal inhibitory concentration: 56700 nM
Compound 4: middle estimate off by 1.1-fold (0.02 log units), on the high side, within the range that was stated.
By their numbers in this assay, from the lowest: compounds 3, 4 and 1 (each within the scatter of the next).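

In this assay compound 2 has no number to set against compound 4 at 56700 nM so no new step can be read from this pair. No supporting data bear on the result. Whether swapping nitro for hydrogen on the aromatic carbon shifts the value stays open, with no pair of numbers among the compounds shown differing in that one place.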